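The source may hold more compounds than are shown below. What is called first, only, known or untested is meant among the compounds shown, and "the series" means these compounds.

Going by the values given here, compound 3 `CN1CCC[C@H]1COc1cncc(Br)c1` gives 0.27 nM in an assay on membranes from brain for displacement of a labelled ligand from Neuronal acetylcholine receptor; alpha4/beta2 (Rattus norvegicus) (on this read-out higher numbers stand for weaker inhibition and lower numbers for stronger inhibition), the lowest of the three numbers known here. Compound 2 `CN1CCC[C@H]1COc1cccnc1I` gives 606 nM in this assay, and compound 1 `CN1CCC[C@H]1COc1cccnc1[N+](=O)[O-]` gives 9000 nM. Compound 3 therefore stands well apart from both, beyond the scatter in each case.

Among the compounds with values here, one measured step bears on the change now in question: a 15-fold lower number from compound 1 to compound 2 (1.17 log units; beyond the scatter), a large move toward stronger inhibition when a halogen took the place of a nitro group. Compound 4 `CN1CCC[C@H]1COc1cncc([N+](=O)[O-])c1` is compound 3 with nitro in place of bromo on an aromatic carbon. This runs in the reverse direction of that step, a nitro group entering where a halogen stood, although on a different core, so the size need not carry over exactly. The expectation is that the number rises, meaning weaker inhibition, with a 15-fold higher number from compound 3 to compound 4 (1.17 log units; beyond the scatter) expected to be of roughly the size seen in the earlier step. Compound 4 is estimated at 4 nM in this assay, with a range from 0.8 nM to 30 nM.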

Compound 4, inhibition constant: 4.65 nM
The estimate for compound 4 lay 1.2-fold (0.07 log units) below the measured number; low and high end bracket the measured number.
By their numbers in this assay, from the lowest: compound 3; then compound 4; then compound 2; then compound 1.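

At this place, an aromatic carbon two atoms from the ring nitrogen, bromo and nitro can now be compared directly on one core, and in this assay the change gives a 17-fold higher number from compound 3 to compound 4 (1.24 log units; beyond the scatter). Going by these compounds alone, the earlier step, a 15-fold lower number from compound 1 to compound 2 (1.17 log units; beyond the scatter), involved a halogen and a nitro group on a different arrangement of the shared parts, so this is the first reading at this place. In both pairs shown, the compound carrying the halogen has the lower number and the step is large, beyond the scatter, although two pairs are too few to establish a general rule.

On these data alone, how an amine, a carboxylic acid or a chloro group would compare at this same place remains open. The data shown also offer no measurement that explains why nitro gives the higher number here.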